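A few compounds are considered here, and "the series" means these few. Any claim that something is new, unique, unknown or untested is made for them only; others in the source may bear on it.

In an ADME assay on the whole organism (Rattus norvegicus, strain Sprague-Dawley), read by LC-MS, with a stated time of 30 min, at a dose of 1 mg/kg by the intravenous route (a lower number here means that the compound disappears faster, a higher number that the compound lasts longer), compound 1 `N#Cc1ccc(O[C@H]2CN(S(=O)(=O)c3ccc(Cl)cc3Cl)C[C@@]2(O)CN)cc1F` gives 3.2 h, the highest of the three numbers in hand. Compound 3 `N#Cc1ccc(S(=O)(=O)[C@H]2CN(S(=O)(=O)c3ccc(Cl)cc3Cl)C[C@@]2(O)CO)cc1` gives 1.7 h, a gap to compound 1 that lies within the usual scatter, while compound 2 `N#Cc1ccc(O[C@H]2CN(S(=O)(=O)c3ccccc3C#N)C[C@@]2(O)CO)cc1F` gives 0.4 h, a gap that lies beyond it. Compound 4 `N#Cc1ccc(O[C@H]2CN(S(=O)(=O)c3ccc(Cl)cn3)C[C@@]2(O)CN)cc1F` has not yet been measured in this assay. It differs from compound 1 in one place: 5-chloropyridin-2-yl in place of 2,4-dichlorophenyl on a sulfonyl sulfur. Among the compounds with values here, no step between measured compounds matches this change, so nothing in hand fixes its size. A modest downward move is expected, of a size that may stay within the scatter, giving an estimated step of a 1.6-fold lower number from compound 1 to compound 4 (0.20 log units; within the scatter). Compound 4 is therefore estimated at 2 h, with a range from 0.8 h to 4.5 h.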

Compound 4, mean residence time in the Rattus norvegicus assay: 2.5 h
Compound 4: the middle estimate sits 1.3-fold (0.10 log units) below what was measured; the measured number falls inside the stated range.
By their numbers in the Rattus norvegicus assay, from the lowest: compound 2; then compounds 3, 4 and 1 (each within the scatter of the next).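

Within the data shown here, until now no step at this position had been read: in the Rattus norvegicus assay, 5-chloropyridin-2-yl in place of 2,4-dichlorophenyl on a sulfonyl sulfur gives a 1.3-fold lower number from compound 1 to compound 4 (0.11 log units; within the scatter). In a physicochemical assay for lipophilicity, at pH 7.4 (on this read-out lower numbers stand for lower lipophilicity and higher numbers for higher lipophilicity), compound 1 gives 4 and compound 4 gives 2.5. In this one pair, then, mean residence time stays within the scatter while lipophilicity drops well beyond it in the physicochemical assay: the measured distribution coefficient of compound 1, 4, and of compound 4, 2.5, a number 1.50 log units lower (beyond the scatter)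

On these data alone, whether the same split holds with the other groups on the sulfonyl sulfur in compound 2 and compound 3 stays open, as this is a single pair. The compounds shown also do not tell how a carboxylic acid or a longer chain would read on that sulfur.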